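A Bicyclic Ether Tested Against a Cyclopentyl Benchmark

The source may hold more compounds than are shown below. What is called first, only, known or untested is meant among the compounds shown, and "the series" means these compounds.

Of the compounds shown here, three have been measured in an assay for inhibition of 15-hydroxyprostaglandin dehydrogenase [NAD(+)] (Homo sapiens), read by fluorescence and spectrophotometry; on this read-out higher numbers stand for weaker inhibition and lower numbers for stronger inhibition. Compound 1 `Cc1ncsc1CCOc1ccc(/C=C2\SC(=O)NC2=O)cc1Cl` gives 5170 nM. Compound 2 `O=C1NC(=O)/C(=C/c2ccc(OC(=O)c3cccs3)c(Cl)c2)S1` gives 264 nM, and compound 3 `O=C1NC(=O)/C(=C/c2ccc(OCC3CCCC3)c(Cl)c2)S1` gives 11 nM, the lowest of the three numbers. Every step between them lies beyond the scatter: a 20-fold lower number from compound 1 to compound 2 (1.29 log units; beyond the scatter), a 470-fold lower number from compound 1 to compound 3 (2.67 log units; beyond the scatter) and a 24-fold lower number from compound 2 to compound 3 (1.38 log units; beyond the scatter). Compound 3 therefore stands apart from both others, with compound 2 the nearer of the two and compound 1 the further.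

Compound 4 `O=C1NC(=O)/C(=C/c2ccc(OCC3CC4CCC3C4)c(Cl)c2)S1` differs from compound 3 in one place: a group of 7 heavy atoms (7 carbon; 2 five-membered non-aromatic rings of carbon only) in place of a group of 5 heavy atoms (5 carbon; one five-membered non-aromatic ring of carbon only), on a saturated chain carbon bound to an oxygen on an aromatic ring. Going by the values given here, the steps that bear on this change are a 470-fold lower number from compound 1 to compound 3 (2.67 log units; beyond the scatter) and a 24-fold lower number from compound 2 to compound 3 (1.38 log units; beyond the scatter), both of which exchanged a 4-methyl-1,3-thiazol-5-yl or a thiophen-2-yl group for a saturated ring of carbon only. Compound 4 keeps a saturated ring of carbon only and adds a second one, so the large gains seen on the way to compound 3 are not expected to recur; what remains is a step of uncertain direction and modest size in this assay. The account expects compound 4 to give 8 nM, between 3 nM and 25 nM. That estimate amounts to a 1.4-fold lower number from compound 3 to compound 4 (0.14 log units; within the scatter), expected to stay within or close to the scatter.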

Compound 4, half-maximal inhibitory concentration: 165 nM
Estimate against measurement, compound 4: 21-fold (1.31 log units) below; measured number above the stated range.
By their numbers in this assay, from the lowest: compound 3; then compounds 4 and 2 (each within the scatter of the next); then compound 1.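

In this assay, the change of cyclopentyl for the group of 7 heavy atoms on the saturated chain carbon is a 15-fold higher number from compound 3 to compound 4 (1.18 log units; beyond the scatter), so a saturated ring of carbon only at this place does not by itself carry the low number of compound 3; the place distinguishes between two groups that have no hydrogen-bond donors or acceptors and no net charge. The step of a 1.6-fold lower number from compound 2 to compound 4 (0.20 log units; within the scatter) is within the scatter, so the added ring gives back the whole advantage that cyclopentyl held over the (thiophen-2-yl)carbonyl group, although the step of a 31-fold lower number from compound 1 to compound 4 (1.50 log units; beyond the scatter) shows that the new group still stays well clear of the 2-(4-methyl-1,3-thiazol-5-yl)ethyl group. No evidence is available that accounts for this result.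

The compounds shown do not separate the effect of the added carbon atoms from that of the second ring. From the compounds shown here alone, how a single ring such as cyclohexyl, or an open longer chain of carbon atoms on the same oxygen, would compare with cyclopentyl remains open.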